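Adding a methyl to compound 3

This account rests on a few compounds, and the source may have more. Where it says the series, first, only, none or still open, it means among the compounds named here.

Going by the values given here, in a functional assay on CCRF-CEM cells (Homo sapiens), with a stated time of 3 days (on this read-out higher numbers stand for weaker inhibition and lower numbers for stronger inhibition), compound 3 (`O=C1C=CCO[C@@H]1n1ccc(O)nc1=O`) gives 82000 nM, the only number among the three measured compounds. Compound 1 (`C=C1[C@H](O)[C@H](O)CO[C@@H]1n1ccc(O)nc1=O`) reads > 800000 nM, which is a limit. Compound 2 (`C=C1[C@H](O)[C@H](O)CO[C@@H]1n1cc(C)c(O)nc1=O`) reads >= 800000 nM, which is likewise a limit.

Compound 4 (`Cc1cn([C@H]2OCC=CC2=O)c(=O)nc1O`) has not yet been measured. It differs from compound 3 by methyl in place of hydrogen on an aromatic carbon, ortho to a hydroxy group: methyl in place of hydrogen on an aromatic carbon. Among the compounds with values here, only one measured step involves the same change, namely a step that the two limits leave unreadable from compound 1 to compound 2. That step has no readable size and shows no direction, so it offers no basis for predicting a shift. No change beyond the usual scatter is therefore expected in this assay, and the expected step is a 1.1-fold lower number from compound 3 to compound 4 (0.04 log units; within the scatter). The range is kept wide, since the estimate rests on a single measured number. Compound 4 is estimated at 75000 nM, with an expected range from 25000 nM to 220000 nM.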

Compound 4, half-maximal inhibitory concentration: 104000 nM
Estimate against measurement, compound 4: 1.4-fold (0.14 log units) below; the range from low to high includes it.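

In this assay, methyl in place of hydrogen on the aromatic carbon, ortho to a hydroxy group, gives a 1.3-fold higher number from compound 3 to compound 4 (0.10 log units; within the scatter), the first readable size for this change at this position. The earlier step with the same change cannot be read, and compound 1 is one end of it, held at a limit: the limit of > 800000 nM in this assay, at which 1 of the 4 values shown sits. Compound 2, the other end, is also held at a limit: the limit of >= 800000 nM in this assay, at which 1 of the 4 values shown sits.

Whether an ethyl group, an amine or a carboxylic acid on this aromatic carbon would give a step beyond the scatter remains open, since hydrogen and methyl are the only groups shown there. Also open, from the compounds shown here alone, is whether methyl has any readable effect on the core of compound 1, where neither value is a number.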